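This account rests on a few compounds, and the source may have more. Where it says the series, first, only, none or still open, it means among the compounds named here.

Compounds measured so far in a functional assay on L1210 cells (Mus musculus), with a stated time of 12 days; on this read-out lower numbers stand for lower potency and higher numbers for higher potency (the scale is a negative logarithm):
compound 1 `CC1=C(N2CC2)C(=O)C(N2CC2)=C(N2CC2)C1=O`, 6.77
compound 2 `CCC(COC(N)=O)C1=C(N2CC2)C(=O)C(C)=C(N2CC2)C1=O`, 6.18
compound 3 `CCC1=C(N2CC2)C(=O)C(CCOC(N)=O)=C(N2CC2)C1=O`, 6.25

Compound 1 stands highest of the three numbers in this assay; compound 3 lies nearest, with a value lower by an amount beyond the usual scatter, and compound 2 lies furthest, also beyond the scatter. The unmeasured compound 4 `COCCC1=C(N2CC2)C(=O)C(C)=C(N2CC2)C1=O` differs from compound 1 in one place: 2-methoxyethyl in place of aziridin-1-yl on a double-bonded ring carbon. Compounds 2 and 3 each carry a chain in place of one aziridin-1-yl group on the shared core and fall below compound 1, so a step downward is expected for compound 4 as well, a number 0.67 log units lower from compound 1 to compound 4 (beyond the scatter), beyond the scatter. Compound 4 is therefore expected to give 6.1, within a range from 5.6 to 6.6.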

Compound 4, logarithm of the reciprocal of the active concentration, log(1/C): 5.57
Compound 4: middle estimate off by 0.53 log units, on the high side; measured number outside the range, below it.
By their numbers in this assay, from the lowest: compound 4; then compounds 2 and 3 (each within the scatter of the next); then compound 1.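

In this assay, among the compounds shown here, the change from aziridin-1-yl to 2-methoxyethyl on this double-bonded ring carbon gives a large drop (a number 1.20 log units lower from compound 1 to compound 4 (beyond the scatter)), the first step on the shared core that can be read at a single place. The leaving and entering groups each count one hydrogen-bond acceptor and no donors, so that count does not separate them. Nothing available here bears on the reason for this step. Going by these compounds, it remains open whether the drop belongs to this particular chain or to any group without the three-membered ring. A dimethylamino group, a simple ethyl chain or a longer ether chain at this place would tell these apart.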